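Moving one chlorine from compound 2 to compound 4

The source may hold more compounds than are shown below. What is called first, only, known or untested is meant among the compounds shown, and "the series" means these compounds.

In a functional assay on B16-F10 cells (Mus musculus) for inhibition, read by MTT assay, with a stated time of 72 h (a higher number here means a weaker inhibitor, a lower number a stronger inhibitor), three closely related compounds have been measured. Compound 1 `CC1(C)CC(NC(=S)Nc2ccc([N+](=O)[O-])cc2)c2cc(Br)ccc2O1` gives 3000 nM. Compound 3 `CC1(C)CC(NC(=S)Nc2ccc([N+](=O)[O-])cc2)c2cc(F)ccc2O1` gives 4000 nM. Compound 2 `CC1(C)CC(NC(=S)Nc2cccc(Cl)c2)c2cc(Br)ccc2O1` gives 7000 nM. The numbers of compound 2 and compound 1 lie further apart than the usual scatter of repeated measurements, with compound 2 the weaker inhibitor of that pair, while the numbers of compound 2 and compound 3 lie within that scatter.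

Compound 4 `CC1(C)CC(NC(=S)Nc2ccccc2Cl)c2cc(Br)ccc2O1` has the same atoms as compound 2, joined differently: 2-chlorophenyl in place of 3-chlorophenyl on an amide-type nitrogen. In words, 2-chlorophenyl stands in place of 3-chlorophenyl on an amide-type nitrogen.

Among the measured compounds shown here, the only measured change confined to one place is a 1.3-fold higher number from compound 1 to compound 3 (0.12 log units; within the scatter), with fluoro in place of bromo on an aromatic carbon. For the measured compounds named here, that change involves another group in another place, so it offers only weak guidance, and no measured pair tests moving the chlorine. The expectation therefore starts from compound 2 at 7000 nM, and no step beyond the scatter is expected in this assay, in either direction. The estimated change is no change at the digits printed from compound 2 to compound 4 (within the scatter). Compound 4 is estimated at 7000 nM, with an expected range from 3000 nM to 16000 nM.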

Compound 4, half-maximal inhibitory concentration: 17000 nM
Beside the measured number, compound 4's estimate is 2.4-fold (0.39 log units) below it; the whole stated range lies below it.
By their numbers in this assay, from the lowest: compounds 1, 3 and 2 (each within the scatter of the next, the first and the last beyond it); then compound 4.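

In this assay, 2-chlorophenyl in place of 3-chlorophenyl on an amide-type nitrogen gives a 2.4-fold higher number from compound 2 to compound 4 (0.39 log units; beyond the scatter), a modest loss of inhibition. Among the compounds shown here, the two groups hold the same heavy atoms and the same aromatic ring, so this pair shows that the location of one chlorine alone can shift the number beyond the usual scatter, whereas the only earlier change confined to one place, fluoro in place of bromo on an aromatic carbon, gave a 1.3-fold higher number from compound 1 to compound 3 (0.12 log units; within the scatter) and stayed within it. Nothing on hand explains why moving the chlorine has this effect, so its cause remains unknown.

The compounds shown do not tell whether moving the chlorine would have a similar effect with fluoro rather than bromo on the shared core. They also leave open how a methoxy group or an amine on the same aromatic ring, in place of the chlorine, would read in this assay, since only a single chlorine move can be compared here.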